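The source may report more compounds than this note shows. Statements on the series, on what has been measured and on what is new or still open speak of the compounds shown alone.

Measured so far:

Compound 1, `O=C(CCl)Nc1ccc(C(=O)/C=C/c2ccccc2)cc1` — in a functional assay on MGC-803 cells (Homo sapiens) for cytotoxicity, read by MTT assay, with a stated time of 72 h (a lower number here means a stronger inhibitor, a higher number a weaker inhibitor), compound 1 gives 6940 nM.
Compound 2, `O=C(CCl)Nc1ccc(C(=O)/C=C/c2ccccc2Cl)cc1` — in this assay compound 2 gives 2750 nM.
Compound 3, `O=C(CSC(=S)N[C@H]1CCOC1=O)Nc1ccc(C(=O)/C=C/c2ccc(Cl)cc2)cc1` — in this assay compound 3 gives 6900 nM.

Compound 3 stands at the second highest of the three numbers; against compound 1 it sits within the scatter, and only compound 2 lies beyond the scatter from it. Within the data shown here, the one step that can be counted is hydrogen in place of chloro on an aromatic carbon, which produced a 2.5-fold higher number from compound 2 to compound 1 (0.40 log units; beyond the scatter). How the core of compound 3 differs from that of compound 2 is not broken down here.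

The unmeasured compound 4, `O=C(CSC(=S)N[C@H]1CCOC1=O)Nc1ccc(C(=O)/C=C/c2ccccc2)cc1`, differs from compound 3 by hydrogen in place of chloro on an aromatic carbon. Among the measured compounds shown here, this is the same kind of change as the one from compound 2 to compound 1, but not the same: in the earlier pair the chloro stood ortho to a large group, in this pair it stands para to a large group. For the measured compounds named here, with only one counted step of this kind, and on a different core, the expectation for compound 4 is loose. Compound 4 is expected to show a 1.4-fold higher number from compound 3 to compound 4 (0.16 log units; within the scatter) in this assay, a step in the same direction but smaller, because a 2.5-fold higher number from compound 2 to compound 1 (0.40 log units; beyond the scatter) was counted with the chloro ortho to a large group, whereas here the chloro stands para to a large group. Compound 4 is therefore estimated at 10000 nM, with a range from 4000 nM to 25000 nM.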

Compound 4, half-maximal inhibitory concentration: 24800 nM
For compound 4 the middle estimate is 2.5-fold (0.39 log units) below the measured one, within the range that was stated.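

In this assay, hydrogen in place of chloro gave a 3.6-fold higher number from compound 3 to compound 4 (0.56 log units; beyond the scatter), and set beside the earlier step, the change carried over from one core to the other in direction and, within the scatter, in size: the same change on two cores in this assay, a 2.5-fold higher number (0.40 log units; beyond the scatter) from compound 2 to compound 1 and a 3.6-fold higher number (0.56 log units; beyond the scatter) from compound 3 to compound 4, 1.4-fold (0.15 log units) apart, within the scatter of two such steps. Among these compounds, this is still only two pairs, and the chloro does not stand at the same place in them: in the newer pair it sits para to a large group, so these pairs cannot separate the effect of the core from that of the chloro's place on the ring, and they give no general rule for the series. The other new step, a group of 10 heavy atoms in place of one chlorine atom on the saturated chain carbon, gave a 3.6-fold higher number from compound 1 to compound 4 (0.55 log units; beyond the scatter), but it stands alone on a single core and says nothing yet about whether that exchange carries over.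

The compounds shown leave open how a 4-chlorophenyl group would behave on the core of compound 1, which would set place and core apart. They also leave open whether a fluoro or methoxy group in place of the chloro, or an amine in place of the chlorine on the chain carbon, would follow the same steps.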